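A few compounds are considered here, and "the series" means these few. Any claim that something is new, unique, unknown or untested is made for them only; others in the source may bear on it.

Compound 1 `Cc1cc(Sc2ccccc2)c(S(C)(=O)=O)cc1C(=O)N=C(N)N`: 14 nM
Compound 2 `Cc1cc(N2CCCC(O)C2)c(S(C)(=O)=O)cc1C(=O)N=C(N)N`: 30 nM

In a functional assay for inhibition of sodium/hydrogen exchanger (Oryctolagus cuniculus) (on this read-out lower numbers stand for stronger inhibition and higher numbers for weaker inhibition), compound 2 stands at the higher of the two numbers. Compound 3 `Cc1cc(Oc2cccnc2)c(S(C)(=O)=O)cc1C(=O)N=C(N)N` differs from compound 2 in one place: (pyridin-3-yl)oxy in place of 3-hydroxypiperidin-1-yl on an aromatic carbon. Going by the values given here, the one step that bears on this change is a 2.1-fold higher number from compound 1 to compound 2 (0.33 log units; beyond the scatter), a modest one. Compound 3 carries an aromatic ring at this position, as compound 1 does, and compound 1 gives 14 nM. For compound 3 a modest move toward lower numbers is therefore expected, a 1.7-fold lower number from compound 2 to compound 3 (0.22 log units; within the scatter). Compound 3 is estimated at 18 nM, with a range from 7 nM to 45 nM.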

Compound 3, half-maximal inhibitory concentration: 8.8 nM
Compound 3: the middle estimate sits 2.0-fold (0.31 log units) above what was measured; the measured number falls inside the stated range.
By their numbers in this assay, from the lowest: compounds 3 and 1 (each within the scatter of the next); then compound 2.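

In this assay, with the same count of heavy atoms leaving and entering, a six-membered aromatic ring linked through oxygen in place of 3-hydroxypiperidin-1-yl gives a 3.4-fold lower number from compound 2 to compound 3 (0.53 log units; beyond the scatter) and so goes with the lower number. Set against phenylsulfanyl, (pyridin-3-yl)oxy gives a 1.6-fold lower number from compound 1 to compound 3 (0.20 log units; within the scatter) and so cannot be told apart from it at this position. No available data explain either step. Still open, going by these compounds, is which part of the change carries the first step: the ring, the linking atom or the hydroxyl. Phenoxy or unsubstituted piperidin-1-yl would bear on this.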